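Chalcone-like enaminones on a pyrazole core: methoxy for chloro

This account rests on a few compounds, and the source may have more. Where it says the series, first, only, none or still open, it means among the compounds named here.

Measured so far:
compound 1 `O=C(/C=C\Nc1ccc(O)cc1)c1cn(-c2ccccc2)nc1-c1ccccc1`, a functional assay on A549 cells (Homo sapiens) for antiproliferative activity, read by MTT assay, with a stated time of 48 h (on this read-out higher numbers stand for weaker inhibition and lower numbers for stronger inhibition), 3210 nM
compound 2 `COc1cc(N/C=C\C(=O)c2cn(-c3ccccc3)nc2-c2ccc(Cl)cc2)cc(OC)c1OC`, this assay 5640 nM

Compound 2 holds the highest of the two numbers, with compound 1 a short way off, within the scatter. Compound 3 `COc1ccc(-c2nn(-c3ccccc3)cc2C(=O)/C=C\Nc2cc(OC)c(OC)c(OC)c2)cc1` differs from compound 2 in one place: methoxy in place of chloro on an aromatic carbon, which one bond further out reads 4-chlorophenyl to 4-methoxyphenyl. Among the measured compounds shown here, no measured pair shows this change, so no direction is supported; the expected step of a 1.1-fold lower number from compound 2 to compound 3 (0.05 log units; within the scatter) is none beyond the scatter. Compound 3 is estimated at 5000 nM, between 1800 nM and 14000 nM.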

Compound 3, half-maximal inhibitory concentration: 11200 nM
The estimate for compound 3 lay 2.2-fold (0.35 log units) below the measured number; measured number inside the range.
By their numbers in this assay, from the lowest: compounds 1, 2 and 3 (each within the scatter of the next, the first and the last beyond it).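

In this assay the change from 4-chlorophenyl to 4-methoxyphenyl now has a measured pair, and the step of a 2.0-fold higher number from compound 2 to compound 3 (0.30 log units; within the scatter) shows that methoxy and chloro are not separated at this position in this one pair. No measurement on hand bears on why the two groups compare this way. As far as these compounds go, whether an amine or a carboxylic acid at this position would give a step beyond the scatter remains open. Also open, from the compounds shown here alone, is whether methoxy for chloro gives the same result on a different substitution pattern at the other end of the enaminone.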